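The source may report more compounds than this note shows. Statements on the series, on what has been measured and on what is new or still open speak of the compounds shown alone.

Working notes on the series. Compound 1 `CCOC(=O)C1=C(O)/C(=C\c2cc(C)n(-c3ccc(F)cc3)c2C)N=C1C` and compound 2 `CCOC(=O)C1=C(C)N/C(=C/c2cc(C)n(-c3ccc(Cl)cc3)c2C)C1=O` share the same core and differ only in the group on the aromatic nitrogen. In an ADME assay on L6 cells (Rattus norvegicus) for cytotoxicity, read by resazurin assay, with a stated time of 72 h (a higher number here means that more compound is needed for the effect, a lower number that less compound is needed), compound 1 gives 140000 nM. In this assay compound 2 gives 100000 nM. Among the measured compounds shown here, the two numbers lie within the scatter of each other, so compound 2 stands level with compound 1 on the only comparison available, and both sit at weak cytotoxicity.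

Compound 3 `CCOC(=O)C1=C(C)N/C(=C/c2cc(C)n(-c3ccncc3)c2C)C1=O` remains to be measured in this assay. It differs from compound 2 in one place: pyridin-4-yl in place of 4-chlorophenyl on an aromatic nitrogen. For the measured compounds named here, no step between two measured compounds covers this change, so the expectation rests on the two numbers at hand alone. The step of a 1.5-fold higher number from compound 2 to compound 3 (0.18 log units; within the scatter) is expected to stay within the scatter, with no clear direction. Compound 3 is expected to give about 150000 nM in this assay, within a range from 60000 nM to 400000 nM.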

Compound 3, half-maximal effective concentration: 100000 nM
Estimate against measurement, compound 3: 1.5-fold (0.18 log units) above; the measured number falls inside the stated range.
By their numbers in this assay, from the lowest: compounds 2, 3 and 1 (each within the scatter of the next).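

In this assay, pyridin-4-yl in place of 4-chlorophenyl on the aromatic nitrogen brings no change at the digits printed from compound 2 to compound 3 (within the scatter). Among the compounds shown here, this is the only step read at this position so far, and it shows that a ring with 1 hetero atom and 1 hydrogen-bond acceptor leaves the number level with that of the carbon-only ring bearing chlorine. Nothing at hand explains why the number holds across this change.

All three compounds shown carry a six-membered aromatic ring on this nitrogen, so it stays open whether a saturated group such as a longer alkyl chain, or a phenyl ring bearing an amine or a carboxylic acid, would move the number beyond the scatter. The ethyl ester and the methyl groups of the shared core also stay open, as no step shown touches them.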